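A few compounds are considered here, and "the series" means these few. Any claim that something is new, unique, unknown or untested is made for them only; others in the source may bear on it.

Measured so far:
compound 1, `CC(C)COC(=O)N1CCN(C(=O)c2nc(Nc3cc(C4CC4)[nH]n3)c3cc(Cl)ccc3n2)C[C@H]1C`: 30.7%
compound 2, `COC(=O)N1CCN(C(=O)c2nc(Nc3cc(C4CC4)[nH]n3)c3cc(Cl)ccc3n2)C[C@H]1C`: 89.6%
compound 3, `CC(OC(=O)C(C)C)OC(=O)N1CCN(C(=O)c2nc(Nc3cc(C4CC4)[nH]n3)c3cc(Cl)ccc3n2)C[C@H]1C`: 25.8%

In an assay for inhibition of serine/threonine-protein kinase PAK 4 (Homo sapiens), read by FRET and Z'-LYTE, with a stated time of 60 min, tested at 5 uM, in the presence of a further agent that is not named here (a higher number here means a stronger effect of the compound at the concentration tested, a lower number a weaker effect), compound 1 stands second highest of the three; compound 3 lies within the scatter of it, while compound 2 is far above it, as the step of a number 58.9 percentage points higher from compound 1 to compound 2 (beyond the scatter) shows. Compound 4, `C[C@@H]1CN(C(=O)c2nc(Nc3cc(C4CC4)[nH]n3)c3cc(Cl)ccc3n2)CCN1C(=O)OCC(Cl)(Cl)Cl`, is not yet measured. It differs from compound 1 by trichloromethyl in place of isopropyl on a saturated chain carbon bound to an oxygen next to a carbonyl group. For the measured compounds named here, two measured steps bear on this change, both at the same place. Shrinking the group to hydrogen gave the large gain a number 58.9 percentage points higher from compound 1 to compound 2 (beyond the scatter); growing it in compound 3 gave only a number 4.9 percentage points lower from compound 1 to compound 3 (within the scatter). The entering trichloromethyl is counted at a size close to the leaving isopropyl, so no step beyond the scatter is expected, a number 1.3 percentage points higher from compound 1 to compound 4 (within the scatter). Compound 4 is therefore estimated at 32%, within 15% to 52%.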

Compound 4, a percentage reported as inhibition, at one concentration (the size of the read-out at that concentration, not a potency): 63%
The estimate for compound 4 lay 31 percentage points below the measured number; the whole stated range lies below it.
By their numbers in this assay, from the lowest: compounds 3 and 1 (each within the scatter of the next); then compound 4; then compound 2.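

At this place, counting heavy atoms does not predict the outcome: trichloromethyl and isopropyl are close in size, yet the change gave a large rise (a number 32.3 percentage points higher from compound 1 to compound 4 (beyond the scatter)). The 2,2,2-trichloroethyl group also reads well above 1-((isopropylcarbonyl)oxy)ethyl (a number 37.2 percentage points higher from compound 3 to compound 4 (beyond the scatter)), though hydrogen on the same saturated chain carbon stays ahead (a number 26.6 percentage points lower from compound 2 to compound 4 (beyond the scatter)). No supporting measurement explains this rise. Going by these compounds, whether the rise depends on chlorine remains open, and how an ethyl or 2,2,2-trifluoroethyl group would read on this oxygen is unknown.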